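Lengthening a hydroxy chain on two related cores

The source may report more compounds than this note shows. Statements on the series, on what has been measured and on what is new or still open speak of the compounds shown alone.

Compound 1, `OCCCN1CCC(c2nc(-c3ccc4ccccc4c3)no2)CC1`: 40400 nM
Compound 2, `OCCCCN1CCC(c2nc(-c3ccc4ccccc4c3)no2)CC1`: 1170 nM
Compound 3, `OCCCN1CCCC[C@H]1c1nc(-c2ccc3ccccc3c2)no1`: 27000 nM

These three compounds were tested in an assay on HepG2 cells for antagonist activity at Bile acid receptor (Homo sapiens), read by a luciferase reporter; a lower number here means a stronger inhibitor, a higher number a weaker inhibitor. Compound 2 differs from compound 1 by hydroxymethyl in place of hydroxy on a saturated chain carbon, three bonds along the chain from an amine nitrogen in a ring, and that change gave a 35-fold lower number from compound 1 to compound 2 (1.54 log units; beyond the scatter). Compound 3 is built from the same atoms as compound 1, joined differently; the difference between the two cores is not broken down here. In this assay the values of compound 3 and compound 1 lie close together.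

Compound 4, `OCCCCN1CCCC[C@H]1c1nc(-c2ccc3ccccc3c2)no1`, has not yet been measured. It differs from compound 3 by hydroxymethyl in place of hydroxy on a saturated chain carbon, three bonds along the chain from an amine nitrogen in a ring, the same change at the same place as before. Because a 35-fold lower number from compound 1 to compound 2 (1.54 log units; beyond the scatter) the same change is expected to lower the number on the core of compound 3 as well. For the measured compounds named here, only one earlier example supports carrying the step over, so the expected step is set somewhat smaller than that one: an 18-fold lower number from compound 3 to compound 4 (1.26 log units; beyond the scatter) is expected. For compound 4 the expected value in this assay is 1500 nM, most likely between 300 nM and 8000 nM.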

Compound 4, half-maximal inhibitory concentration: 7000 nM
Estimate against measurement, compound 4: 4.7-fold (0.67 log units) below, within the range that was stated.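

In this assay, going from 3-hydroxypropyl to 4-hydroxybutyl on the core of compound 3 gave a 3.9-fold lower number from compound 3 to compound 4 (0.59 log units; beyond the scatter) and so the direction of the change carried over from the core of compound 1. Its size did not carry over, and a step measured on one core was a poor guide to the size of the step on the other: the same change on two cores in this assay, a 35-fold lower number (1.54 log units; beyond the scatter) from compound 1 to compound 2 and a 3.9-fold lower number (0.59 log units; beyond the scatter) from compound 3 to compound 4, 9.0-fold (0.95 log units) apart, beyond the scatter of two such steps
These two pairs show only that the direction held here; they do not explain the gap or give a rule for other cores in this series.

The compounds shown leave open whether a longer chain would lower the number further. They also leave open whether the hydroxy group itself matters, which an amine or a carboxylic acid at the chain end could test.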